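The compounds below may be only part of what the source reports. "The series", "measured", "known", "first", "only" and "open" are said of these compounds alone.

Measured so far:
- compound 1 `[C-]#[N+]Cc1c(C)nc2c(OCc3ccccc3)cccn12`: 94%
- compound 2 `Cc1nc2c(OCc3ccccc3)cccn2c1COC(=O)C(C)(C)C`: 43%

Compound 2 stands lowest of the two numbers in a functional assay on the whole organism (stomach) for inhibition, with Canis familiaris (Canis lupus familiaris) as the target, at a dose of 2 mg/kg by the intravenous route; a lower number here means a weaker effect, a higher number a stronger effect of the compound at the dose given; its nearest neighbour is compound 1, which in this assay gives 94%, a gap beyond the scatter.

Compound 3 `CCc1c(C)nc2c(OCc3ccccc3)cccn12` is not yet measured. It differs from compound 2 by methyl in place of ((tert-butyl)carbonyl)oxy on a saturated chain carbon bound to an aromatic carbon, the same difference read one bond further out being (((tert-butyl)carbonyl)oxy)methyl to ethyl.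

Among the compounds with values here, only one measured step bears on this change: a number 51 percentage points lower from compound 1 to compound 2 (beyond the scatter). That step shows the arrival of the ((tert-butyl)carbonyl)oxy group, in place of a much smaller group at the same saturated chain carbon, going together with a large loss. Compound 3 removes that group again, but what enters is methyl, not the group compound 1 carries, so the recovery need not be complete. The expected step is therefore upward, likely beyond the scatter, but with wide uncertainty: a number 22 percentage points higher from compound 2 to compound 3 (beyond the scatter) is the estimated change from compound 2 to compound 3.

For compound 3 the estimate in this assay is 65%, with a range from 30% to 95%.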

Compound 3, a percentage reported as inhibition, in the whole organism at one dose (the size of the read-out at that dose, not a potency): 37%
The estimate for compound 3 lay 28 percentage points above the measured number, within the range that was stated.
By their numbers in this assay, from the lowest: compounds 3 and 2 (each within the scatter of the next); then compound 1.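

In this assay, methyl in place of ((tert-butyl)carbonyl)oxy on the saturated chain carbon bound to an aromatic carbon gives a number 6 percentage points lower from compound 2 to compound 3 (within the scatter), so two groups very different in size leave the read-out at the same level, and the bulk of the ((tert-butyl)carbonyl)oxy group cannot be read as what separates compound 2 from compound 1. One carbon atom in place of the two-atom carbon and nitrogen group of compound 1 gives a number 57 percentage points lower from compound 1 to compound 3 (beyond the scatter), and together with the earlier step this shows that, among the three groups compared at this carbon, only the group of compound 1 goes with the high number. Nothing available explains why this group stands apart from the other two.

On these data alone, it remains open whether the high number is specific to the carbon and nitrogen group of compound 1 or would also appear with a nitrile, an amine or a hydroxyl group on the same carbon. As far as these compounds go, it is also open whether a longer chain there would stay level with compound 3, and whether the pattern holds at doses other than the single one tested.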